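Three esters on one core, and a fourth to come

This account rests on a few compounds, and the source may have more. Where it says the series, first, only, none or still open, it means among the compounds named here.

Compound 1, `O=C(CCCCCc1ccccc1)OCC1COCCOCCOCCOCCOCCO1`, in a functional assay on HBL-100 cells (Homo sapiens) for inhibition, read by sulforhodamine B assay, with a stated time of 48 h (a higher number here means a weaker inhibitor of growth, a lower number a stronger inhibitor of growth), compound 1 gives 64000 nM.
Compound 2, `CC/C=C/CC(=O)OCC1COCCOCCOCCOCCOCCO1`; in this assay compound 2 gives > 100000 nM, which is a limit of the assay and not a number.
Compound 3, `O=C(OCC1COCCOCCOCCOCCOCCO1)c1cccc(-c2ccc(Br)cc2)c1`, in this assay compound 3 gives 6400 nM.

Going by the values given here, compound 2 therefore stands only as a limit: among the three measured compounds it is the one whose value is not a number, as noted in the limit of > 100000 nM in this assay, at which 1 of the 3 values shown sits. Compound 1 and compound 3 both give numbers in this assay.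

The compound still to be measured is compound 4, `CC(=O)OCC1COCCOCCOCCOCCOCCO1`. It differs from compound 2 by hydrogen in place of but-1-en-1-yl on a saturated chain carbon bound to a carbonyl carbon. Among the compounds with values here, the one measured step that touches the same place is an at least 1.5-fold higher number from compound 1 to compound 2 (0.19 log units; that floor lies within the scatter), which ends at the limit and so shows only a floor. Going from compound 2 to compound 4 removes the whole remaining chain at that place, and the single step in hand gives no sign that a shorter group at this position lowers the number. The account therefore expects compound 4 to stay at or beyond the limit, with a step that the limit leaves unreadable from compound 2 to compound 4 as the expected step. For compound 4 the estimate in this assay is 200000 nM, within a range from 60000 nM to 700000 nM.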

Compound 4, concentration for 50% growth inhibition: > 100000 nM
Compound 4: a limit, no number (the forecaster's own chance of this, stated with the estimate: 80%); the middle value does not contradict the limit.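

With hydrogen on a saturated chain carbon bound to a carbonyl carbon, this assay gains a second compound that ends at a limit and not a number, so removing but-1-en-1-yl altogether brings no number back: the limit of > 100000 nM in this assay, at which 2 of the 4 values shown sit.

Replacing 4-phenylbutyl with hydrogen gives an at least 1.5-fold higher number from compound 1 to compound 4 (0.19 log units; that floor lies within the scatter), a floor set by the limit, so this step alone does not separate compound 4 from compound 1. The step between compound 2 and compound 4 cannot be read, as both ends are limits, and hydrogen and but-1-en-1-yl therefore cannot be ranked against each other.

The compounds shown leave open how the number would move with an amine, a carboxylic acid or a chain longer than 4-phenylbutyl at this place. They also leave open how far past the limit compound 2 and compound 4 lie, and so whether the true step from compound 1 to either of them is large or lies within the usual scatter.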